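The source may hold more compounds than are shown below. What is called first, only, known or untested is meant among the compounds shown, and "the series" means these compounds.

Compound 1 `CC1=NN(C(=O)/C=C/c2ccccc2)C(c2ccccc2O)C1` — in a functional assay on HepG2 cells (Homo sapiens) for cytotoxicity, read by MTT assay, with a stated time of 48 h (a higher number here means a weaker inhibitor, a lower number a stronger inhibitor), compound 1 gives 29000 nM.
Compound 2 `CCC(=O)N1N=C(c2cc3ccccc3oc2=O)CC1c1ccccc1` — in this assay compound 2 gives 9610 nM.

Of the two measured compounds, compound 2 stands with the lower number. Its nearest neighbour is compound 1, whose number is higher by a margin that lies beyond the usual scatter, so compound 2 is the stronger inhibitor of the pair on these data.

Compound 3 `NC(=O)C1CCN(CC(=O)N2N=C(c3cc4ccccc4oc3=O)CC2c2ccccc2)CC1` has not yet been measured. It differs from compound 2 in one place: 4-carbamoylpiperidin-1-yl in place of methyl on a saturated chain carbon bound to a carbonyl carbon. For the measured compounds named here, no step between two measured compounds shows what such a change does here, so the expectation for compound 3 rests on compound 2 alone and on the size of the group that enters. Given that compound 2 gives 9610 nM, the step from compound 2 to compound 3 is expected to be small, if anything toward a slightly higher number, and may well fall within the scatter; the expected step is a 1.2-fold higher number from compound 2 to compound 3 (0.10 log units; within the scatter). Compound 3 is therefore estimated at 12000 nM, with a range from 4000 nM to 40000 nM.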

Compound 3, half-maximal inhibitory concentration: 19300 nM
Estimate against measurement, compound 3: 1.6-fold (0.21 log units) below, and the stated range covers the measured number.
By their numbers in this assay, from the lowest: compounds 2, 3 and 1 (each within the scatter of the next, the first and the last beyond it).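

Read in this assay, the exchange of methyl for 4-carbamoylpiperidin-1-yl on a saturated chain carbon bound to a carbonyl carbon gives a 2.0-fold higher number from compound 2 to compound 3 (0.30 log units; within the scatter), the first step available at this position. The position therefore takes a much larger group, bringing a six-membered non-aromatic ring, a hydrogen-bond donor and hydrogen-bond acceptors, without a shift that lies beyond the scatter, so neither the added size nor the added ring separates compound 3 from compound 2 on these data. Nothing at hand explains why the step is this small, and no supporting measurement bears on it.

For the compounds shown here, with only this one step, the contributions of the piperidine ring and of its carboxamide cannot be told apart, and a plain piperidin-1-yl, a morpholin-4-yl or a piperidine bearing a carboxylic acid in place of the carboxamide would be needed to pull them apart. On these data alone, it also remains open whether a simple amine such as dimethylamino or a longer chain at this position would leave the number within the scatter of compound 2, or would move it beyond.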